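The compounds below may be only part of what the source reports. "The series", "measured", "known", "first", "only" and "open" are said of these compounds alone.

Among the compounds with values here, in a functional assay on HeLa cells (Homo sapiens) for inhibition (on this read-out higher numbers stand for weaker inhibition and lower numbers for stronger inhibition), compound 1 `Cc1cn(/C=C/C=O)c(=O)[nH]c1=O` gives 25000 nM, the only true number among the three compounds tested so far. Compound 2 `Nc1nc(O)c2ncn(/C=C/C=O)c2n1` reads > 100000 nM, which is a limit of the assay and not a number. Compound 3 `CC(=O)/C=C/n1cc(C)c(=O)[nH]c1=O` reads > 100000 nM, which is also a limit. The data are thus marked by the limit of > 100000 nM in this assay, at which 2 of the 3 values shown sit.

Compound 4 `O=C/C=C/n1cc(CO)c(=O)[nH]c1=O` keeps the core of compound 1 and carries one change, (hydroxy in place of hydrogen on a saturated chain carbon bound to an aromatic carbon), which turns methyl into hydroxymethyl. Within the data shown here, only one measured step can serve as a guide, and it lies at a different place: methyl in place of hydrogen on a carbonyl carbon gave an at least 4.0-fold higher number from compound 1 to compound 3 (0.60 log units; beyond the scatter). That step shows that a single small addition to compound 1 can lower inhibition, but it does not set a size for the new change. A small move toward weaker inhibition is therefore expected, and the expected step is a 1.8-fold higher number from compound 1 to compound 4 (0.26 log units; within the scatter). The estimate for compound 4 is 45000 nM, with an expected range from 15000 nM to 100000 nM.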

Compound 4, half-maximal inhibitory concentration: > 100000 nM
Compound 4: a limit, no number (the forecaster's own chance of this, stated with the estimate: 30%); middle value at least 2.2-fold (0.34 log units) away from the limit.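

In this assay, the methyl group of compound 1 turns out to be sensitive to a very small edit, since changing it to hydroxymethyl gives an at least 4.0-fold higher number from compound 1 to compound 4 (0.60 log units; beyond the scatter). The earlier step showed a loss of inhibition only for a change on the carbonyl carbon, so inhibition now proves open to loss at a second, separate place on compound 1. The full size of the new step cannot be given because compound 4 reads as a limit of the assay and not a number: the limit of > 100000 nM in this assay, at which 3 of the 4 values shown sit.

Within the data shown here, compound 1 is still the only compound with a true number, so it remains open whether any change at this place can keep or strengthen inhibition. An aminomethyl group, a methoxymethyl group or a longer chain such as ethyl in place of the methyl would show whether the loss is specific to hydroxy.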